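Lengthening the Alkyl Chain of Compound 3 by Four Carbons

A few compounds are considered here, and "the series" means these few. Any claim that something is new, unique, unknown or untested is made for them only; others in the source may bear on it.

In a functional assay on MCF7 cells (Homo sapiens) for cytotoxicity, read by MTT assay, with a stated time of 48 h (a higher number here means a weaker inhibitor, a lower number a stronger inhibitor), compound 3 `CCCCCCCCNC(=O)[C@@H](NC(=O)c1nccc2ccccc12)[C@@H](C)O` gives 63200 nM, the highest number among the three measured compounds. Compound 2 `CCCCCCCCCCCCCCCCCCNC(=O)[C@@H](N)[C@@H](C)O` gives 27400 nM, and compound 1 `CCCCCCCCCCCCCCNC(=O)[C@@H](N)[C@@H](C)O` gives 10700 nM. Compound 4 `CCCCCCCCCCCCNC(=O)[C@@H](NC(=O)c1nccc2ccccc12)[C@@H](C)O` differs from compound 3 by butyl in place of hydrogen on a saturated chain carbon, eight bonds along the chain from an amide-type nitrogen. For the measured compounds named here, the only measured step of the same kind is a 2.6-fold higher number from compound 1 to compound 2 (0.41 log units; beyond the scatter), which also added a butyl to the saturated chain and moved the number higher. On that basis, the step in this assay is expected to be modest and towards a higher number, estimated as a 1.9-fold higher number from compound 3 to compound 4 (0.28 log units; within the scatter). Compound 4 is therefore expected to give about 120000 nM, with a likely range from 45000 nM to 320000 nM.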

Compound 4, half-maximal inhibitory concentration: 50500 nM
Compound 4: middle estimate off by 2.4-fold (0.38 log units), on the high side, within the range that was stated.
By their numbers in this assay, from the lowest: compound 1; then compounds 2, 4 and 3 (each within the scatter of the next, the first and the last beyond it).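

In this assay, butyl in place of hydrogen on a saturated chain carbon, eight bonds along the chain from an amide-type nitrogen, gives a 1.3-fold lower number from compound 3 to compound 4 (0.10 log units; within the scatter), so on this core the added chain length has no readable effect. The step seen earlier therefore does not carry over as a general rule for lengthening the chain: the same change on two cores in this assay, a 2.6-fold higher number (0.41 log units; beyond the scatter) from compound 1 to compound 2 and a 1.3-fold lower number (0.10 log units; within the scatter) from compound 3 to compound 4, 3.2-fold (0.51 log units) apart, beyond the scatter of two such steps

The two steps differ in both core and place along the chain, and the compounds shown cannot separate these. As far as these compounds go, whether a longer chain, or an amine or carboxylic acid in place of the butyl, would move the number on the core of compound 3 remains open.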